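The source may report more compounds than this note shows. Statements on the series, on what has been measured and on what is new or still open speak of the compounds shown alone.

Measured compounds:
compound 1, `Cc1cc(C)c(NC(=O)N(Cc2ccc(-c3nnc(C)o3)cc2)C2CCCCCC2)c(C)c1`: 27 nM
compound 2, `Cc1cc(C)c(NC(=O)N(Cc2ccc(-n3cccn3)cc2)C2CCCCCC2)c(C)c1`: 70 nM
compound 3, `Cc1cc(C)c(NC(=O)N(Cc2ccc(-c3cn[nH]c3)cc2)C2CCCCCC2)c(C)c1`: 270 nM

These three compounds share one core and differ only in the five-membered ring that sits on the outer benzene ring. In an assay on microsomes from intestine for inhibition of acyl-CoA:cholesterol acyltransferase (Oryctolagus cuniculus) (a higher number here means a weaker inhibitor, a lower number a stronger inhibitor), compound 3 gives the highest number of the three, so it is the weakest inhibitor here: a 3.9-fold higher number from compound 2 to compound 3 (0.59 log units; beyond the scatter) and a 10-fold higher number from compound 1 to compound 3 (1.00 log units; beyond the scatter) both lie beyond the scatter.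

Compound 4, `Cc1cc(C)c(NC(=O)N(Cc2ccc(-c3ccn(C)n3)cc2)C2CCCCCC2)c(C)c1`, is not yet measured. It changes compound 3 in one place: 1-methyl-1H-pyrazol-3-yl in place of 1H-pyrazol-4-yl on an aromatic carbon. For the measured compounds named here, two measured steps bear on this. a 3.9-fold higher number from compound 2 to compound 3 (0.59 log units; beyond the scatter) shows that moving from one pyrazole attachment to another shifts the number beyond the scatter, and a 10-fold higher number from compound 1 to compound 3 (1.00 log units; beyond the scatter) shows that a methyl-bearing five-membered ring without a ring hydrogen sits at the low end of the range. Compound 4 also carries a methyl group and has no ring hydrogen, so a modest step toward a lower number is expected in this assay, roughly the size of the step seen between compound 2 and compound 3.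

For compound 4 the expected value is 60 nM, with a likely range from 20 nM to 180 nM, which would be a step of a 4.5-fold lower number from compound 3 to compound 4 (0.65 log units; beyond the scatter) from compound 3.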

Compound 4, half-maximal inhibitory concentration: 44 nM
Compound 4: middle estimate off by 1.4-fold (0.13 log units), on the high side; the range from low to high includes it.
By their numbers in this assay, from the lowest: compounds 1, 4 and 2 (each within the scatter of the next, the first and the last beyond it); then compound 3.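

In this assay, swapping 1H-pyrazol-4-yl for 1-methyl-1H-pyrazol-3-yl gives a 6.1-fold lower number from compound 3 to compound 4 (0.79 log units; beyond the scatter) and shows that a pyrazole at this place, on an aromatic carbon para to a large group, is compatible with a much lower number than compound 3 suggested. The new compound cannot be told apart from either of the two stronger inhibitors, with a 1.6-fold lower number from compound 2 to compound 4 (0.20 log units; within the scatter) and a 1.6-fold higher number from compound 1 to compound 4 (0.21 log units; within the scatter), even though the numbers of compound 1 and compound 2 lie beyond the scatter of each other. This one change moves the ring's attachment point, adds a methyl group and removes the hydrogen-bond donor, and no measurement available here explains the step or assigns it to any of these.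

The compounds shown leave open which of these changes carries the step, a question that the 1-methyl-1H-pyrazol-4-yl and 1H-pyrazol-3-yl groups could help separate. Also open, going by these compounds, is how the number would respond to an amine or a carboxylic acid at this same place.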